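Bromo in place of methoxy: what to expect for compound 4

The source may report more compounds than this note shows. Statements on the series, on what has been measured and on what is new or still open speak of the compounds shown alone.

Measured so far in a functional assay (aorta) with Rattus norvegicus as the target; a higher number here means a more potent compound, by a factor of ten per unit of this negative logarithm, a lower number a less potent compound:
compound 1 `COc1ccc2c(c1)C(n1ccccc1=O)=CC(C)(C)O2`: 6.55
compound 2 `CC1(C)C=C(n2ccccc2=O)c2cc(OCC(=O)c3ccccc3)ccc2O1`: 5.05
compound 3 `CC1(C)C=C(n2ccccc2=O)c2cc(OCC(=O)c3ccc(F)cc3)ccc2O1`: 4.63

Compound 1 stands highest of the three: the step of a number 1.50 log units lower from compound 1 to compound 2 (beyond the scatter) and the step of a number 1.92 log units lower from compound 1 to compound 3 (beyond the scatter) are both large, while a number 0.42 log units lower from compound 2 to compound 3 (beyond the scatter) is modest. Compound 4 `CC1(C)C=C(n2ccccc2=O)c2cc(Br)ccc2O1` differs from compound 1 by bromo in place of methoxy on an aromatic carbon. Among the measured compounds shown here, no measured step covers an exchange of this kind; the two large drops from compound 1 came from adding a benzoyl or a (4-fluorophenyl)carbonyl on a saturated chain carbon bound to an oxygen on an aromatic ring, not from removing the methoxy itself. With nothing directly comparable, a step of a number 0.35 log units lower from compound 1 to compound 4 (beyond the scatter) in this assay is expected, with a wide margin. Compound 4 is estimated at 6.2, between 5.4 and 7.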

Compound 4, logarithm of the reciprocal of the active concentration, log(1/C): 7.84
Compound 4: middle estimate off by 1.64 log units, on the low side; measured number above the stated range.
By their numbers in this assay, from the lowest: compound 3; then compound 2; then compound 1; then compound 4.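

In this assay, among the compounds shown here, this aromatic carbon is not only a place where changes lower the number: bromo in place of methoxy gives a number 1.29 log units higher from compound 1 to compound 4 (beyond the scatter), whereas the earlier steps from compound 1 all went down. A group without an ether oxygen and with no hydrogen-bond acceptor is therefore compatible with a higher number here. No supporting measurement bears on why this exchange raises the number.

Still open, on these data alone, is whether the rise belongs to bromo itself or to the loss of methoxy. Chloro, methyl or an amine on this carbon would help separate the two readings.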